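Aryl ketone thioether series: methoxy in place of phenyl

A few compounds are considered here, and "the series" means these few. Any claim that something is new, unique, unknown or untested is made for them only; others in the source may bear on it.

Compound 1 `CCOC(=O)c1ccc(Nc2ccnc(SCC(=O)c3ccc([N+](=O)[O-])cc3)n2)cc1` gives 33% in a functional assay on PC-3 cells (Homo sapiens) for inhibition, read by sulforhodamine B assay, with a stated time of 48 h, tested at 10 uM; on this read-out lower numbers stand for less inhibition of growth and higher numbers for more inhibition of growth at the one concentration tested; compound 2 `CCOC(=O)c1ccc(Nc2ccnc(SCC(=O)c3ccc(C#N)cc3)n2)cc1` gives 60%; compound 3 `CC(=O)c1cccc(Nc2ccnc(SCC(=O)c3ccc(-c4ccccc4)cc3)n2)c1` gives 25%. Compound 3 thus holds the lowest of the three numbers, though its gap to compound 1 lies within the scatter, while compound 2 stands beyond the scatter above it. Compound 4 `COc1ccc(C(=O)CSc2nccc(Nc3cccc(C(C)=O)c3)n2)cc1` is the next member, carrying (methoxy in place of phenyl on an aromatic carbon). Within the data shown here, no measured step bears directly on this exchange; the one step in hand, a number 27 percentage points higher from compound 1 to compound 2 (beyond the scatter), concerned a different exchange on an aromatic carbon and was modest. A step of similar or smaller size is therefore expected for compound 4, with no clear direction. For compound 4 the estimate is 35%, with a range of 15% to 60%, meaning an expected step of a number 10 percentage points higher from compound 3 to compound 4 (within the scatter).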

Compound 4, percent growth inhibition at one concentration: 37%
Compound 4: middle estimate off by 2 percentage points, on the low side; low and high end bracket the measured number.
By their numbers in this assay, from the lowest: compounds 3, 1 and 4 (each within the scatter of the next, the first and the last beyond it); then compound 2.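

In this assay, methoxy in place of phenyl on an aromatic carbon, para to a large group, gives a number 12 percentage points higher from compound 3 to compound 4 (beyond the scatter). The outer aromatic ring is therefore not needed at this place to hold growth inhibition at this level, and the smaller group does not lower the number. No available measurement accounts for this step.

Still open, on these data alone, is whether an amine, a carboxylic acid or a longer alkoxy chain at this place would shift the number further. Also open, as far as these compounds go, is whether methoxy would give a similar step on the core of compound 1.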